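A Hydroxy Group Gives Way on the Phenyl Ring

The compounds below may be only part of what the source reports. "The series", "measured", "known", "first", "only" and "open" are said of these compounds alone.

Compound 1 `Clc1ccc(-c2nnc(SCCCN3CCN(c4nc5ccccc5o4)CC3)o2)cc1` gives 89600 nM
Compound 2 `Oc1ccc(-c2nnc(SCCCN3CCN(c4nc5ccccc5o4)CC3)o2)cc1` gives 117000 nM

Going by the values given here, in a functional assay on A-431 cells (Homo sapiens) for inhibition, read by MTT assay, with a stated time of 72 h (a lower number here means a stronger inhibitor, a higher number a weaker inhibitor), compound 2 gives 117000 nM and so stands within the scatter of compound 1, the only other compound measured. Compound 3 `c1ccc(-c2nnc(SCCCN3CCN(c4nc5ccccc5o4)CC3)o2)cc1` differs from compound 2 by hydrogen in place of hydroxy on an aromatic carbon in one place, with hydrogen in place of hydroxy on an aromatic carbon, or 4-hydroxyphenyl to phenyl. Among the compounds with values here, only one measured step touches this group, hydroxy in place of chloro, and a 1.3-fold higher number from compound 1 to compound 2 (0.12 log units; within the scatter) lies within the scatter. Within the data shown here, no measured compound yet carries hydrogen there, so this evidence is indirect. A step beyond the scatter in this assay is therefore not expected, in either direction. The expected step is a 1.2-fold lower number from compound 2 to compound 3 (0.07 log units; within the scatter) and stays within the scatter. Compound 3 is estimated at 100000 nM (expected range 50000 nM to 200000 nM).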

Compound 3, half-maximal inhibitory concentration: 57600 nM
The estimate for compound 3 lay 1.7-fold (0.24 log units) above the measured number; measured number inside the range.
By their numbers in this assay, from the lowest: compounds 3, 1 and 2 (each within the scatter of the next, the first and the last beyond it).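

In this assay, hydrogen in place of hydroxy on the aromatic carbon para to a large group gives a 2.0-fold lower number from compound 2 to compound 3 (0.31 log units; beyond the scatter), a modest step but the first among these compounds to pass beyond the scatter. Hydrogen in place of chloro at the same place gives a 1.6-fold lower number from compound 1 to compound 3 (0.19 log units; within the scatter), and the earlier step between chloro and hydroxy also stayed within the scatter, so only the hydroxy and hydrogen pair is separated and chloro cannot be told apart from either. No evidence is available that would explain the step on the phenyl ring.

The compounds shown leave open how an amine, a methoxy group or a carboxylic acid would read at this same place. They also leave open whether a longer chain in the shared core would change these numbers or the small separation among the three groups.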